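Replacing one methoxy with methyl in compound 2

The compounds below may be only part of what the source reports. "The series", "measured", "known", "first", "only" and "open" are said of these compounds alone.

Compound 1 `CCN(CC)C(=S)SC(CC(=O)c1ccccc1)c1ccc(C)cc1` and compound 2 `CCN(CC)C(=S)SC(CC(=O)c1ccc(OC)cc1)c1ccc(OC)cc1` differ in more than one place. In a functional assay on MCF7 cells (Homo sapiens) for cytotoxicity, read by MTT assay, with a stated time of 48 h (a higher number here means a weaker inhibitor, a lower number a stronger inhibitor), compound 1 gives 20000 nM, while compound 2 gives 800 nM. Compound 2 therefore holds the lower of the two numbers, and the gap lies beyond the scatter. Compound 3 `CCN(CC)C(=S)SC(CC(=O)c1ccc(OC)cc1)c1ccc(C)cc1` departs from compound 2 by one change, methyl in place of methoxy on an aromatic carbon, para to a large group. Among the compounds with values here, no single-place step has been measured to guide the expectation. Compound 3 shares its 4-methylphenyl with compound 1 at 20000 nM and keeps a 4-methoxyphenyl found in compound 2 at 800 nM. A rise beyond the scatter is therefore expected in this assay, estimated as the step of a 4.4-fold higher number from compound 2 to compound 3 (0.64 log units; beyond the scatter). For compound 3 the expected value is 3500 nM, within an estimated range of 1200 nM to 10000 nM.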

Compound 3, half-maximal inhibitory concentration: 17000 nM
Beside the measured number, compound 3's estimate is 4.9-fold (0.69 log units) below it, and the stated range ends below it.
By their numbers in this assay, from the lowest: compound 2; then compounds 3 and 1 (each within the scatter of the next).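

In this assay, a single exchange at this position, para to a large group, accounts for nearly all of the gap seen earlier: the step is a 21-fold higher number from compound 2 to compound 3 (1.33 log units; beyond the scatter). The methoxy that compound 3 retains on its other aromatic ring shows no such weight when the methyl is present, since the step for methoxy in place of hydrogen is a 1.2-fold lower number from compound 1 to compound 3 (0.07 log units; within the scatter). Nothing given here accounts for this contrast between the two places.

The compounds shown leave open whether a hydroxyl, a chlorine or a dimethylamino group at this position would keep the number close to that of compound 2. Also open, on these data alone, is what the second methoxy contributes when the 4-methoxyphenyl at this position is present.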